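Sulfamate Amides: Swapping a Diamine for a Bromobenzyl Group

A few compounds are considered here, and "the series" means these few. Any claim that something is new, unique, unknown or untested is made for them only; others in the source may bear on it.

Three sulfamate amides were tested in an assay on HEK293 cells for inhibition of Steryl-sulfatase (Homo sapiens), tested at 0.1 uM; a higher number here means a stronger effect of the compound at the concentration tested, a lower number a weaker effect. Compound 1 `NS(=O)(=O)Oc1ccc2c(c1)CN(C(=O)c1cccc(N3CCC(Cc4ccccc4)CC3)c1)CC2` gives 1.4%, compound 2 `CN(C)CCN(CCN(C)C)c1ccc(C(=O)N2CCc3ccc(OS(N)(=O)=O)cc3C2)cc1` gives 3.8%, and compound 3 `CN(C)CCCN(Cc1ccccc1)c1cccc(C(=O)N2CCc3ccc(OS(N)(=O)=O)cc3C2)c1` gives 23.8%. Compound 2 thus holds the second highest of the three numbers; its nearest neighbour is compound 1, within the usual scatter, while compound 3 sits beyond the scatter above it. Compound 4 `CCN(Cc1ccc(Br)cc1)c1ccc(C(=O)N2CCc3ccc(OS(N)(=O)=O)cc3C2)cc1` has not been measured. It differs from compound 2 in one place: (4-bromobenzyl)(ethyl)amino in place of bis(2-(dimethylamino)ethyl)amino on an aromatic carbon. The expectation rests only on what compound 2 shows at 3.8% and what compound 3 shows at 23.8%. A modest upward step of a number 10.2 percentage points higher from compound 2 to compound 4 (beyond the scatter) is expected, near the edge of the scatter. Compound 4 is accordingly estimated at 14%, with a range from 2% to 35%.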

Compound 4, a percentage reported as inhibition, at one concentration (the size of the read-out at that concentration, not a potency): 78.2%
Beside the measured number, compound 4's estimate is 64.2 percentage points below it; measured number above the stated range.
By their numbers in this assay, from the lowest: compounds 1 and 2 (each within the scatter of the next); then compound 3; then compound 4.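

On an aromatic carbon para to a large group, (4-bromobenzyl)(ethyl)amino in place of bis(2-(dimethylamino)ethyl)amino gives a number 74.4 percentage points higher from compound 2 to compound 4 (beyond the scatter) in this assay, so this position strongly affects the read-out. Both groups count 11 heavy atoms, so the step comes with no change in that count, only with a bromine and an aromatic ring entering as the dimethylamino chains leave. Nothing at hand explains the step.

Open remains which part carries it: the bromine, the benzyl ring, the ethyl or the departure of those chains. A 4-chlorobenzyl or an unsubstituted benzyl group at this place would bear on that question.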